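A few compounds are considered here, and "the series" means these few. Any claim that something is new, unique, unknown or untested is made for them only; others in the source may bear on it.

Measured in a functional assay on KB cells (Homo sapiens) for antiproliferative activity, read by sulforhodamine B assay, with a stated time of 72 h; a lower number here means a stronger inhibitor, a higher number a weaker inhibitor:
- Compound 1 `COc1cc2occ(-c3csc4ccccc34)c(=O)c2c(OC)c1OC`: 820 nM
- Compound 2 `COc1cc2occ(-c3csc4ccccc34)c(=O)c2cc1OC`: > 10000 nM

The entry for compound 2, > 10000 nM, is a limit of the assay and not a number. Compound 3 `COc1cc2c(=O)c(-c3csc4ccccc34)coc2c(OC)c1OC` differs from compound 2 by one change, methoxy in place of hydrogen on an aromatic carbon. Among the measured compounds shown here, one measured step bears on this, an at least 12-fold higher number from compound 1 to compound 2 (1.08 log units; beyond the scatter), which is large and beyond the scatter. It shows that losing a methoxy from the same ring can cost much activity. For the measured compounds named here, the methoxy gained in compound 3 sits on a different aromatic carbon from the one lost in that step, so the guide is indirect. A gain is therefore expected, probably smaller than that measured step. The expected change in this assay is an at least 3.3-fold lower number from compound 2 to compound 3 (0.52 log units; beyond the scatter), towards a lower number. The estimate for compound 3 is 3000 nM, with an expected range of 600 nM to 10000 nM.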

Compound 3, half-maximal inhibitory concentration: > 10000 nM
Compound 3 was reported as a limit; the forecaster's own chance of this, stated with the estimate: 35%; middle value at least 3.3-fold (0.52 log units) away from the limit.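

No step can be read from compound 2 to compound 3, because both entries are limits of the assay and not numbers: the limit of > 10000 nM in this assay, at which 2 of the 3 values shown sit. The compounds shown leave open how far either compound lies beyond that limit, and so whether the methoxy gained in compound 3 changes the activity at all.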